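From thiophene to naphthalene on a shared amide core

A few compounds are considered here, and "the series" means these few. Any claim that something is new, unique, unknown or untested is made for them only; others in the source may bear on it.

Of the compounds shown here, three built on the same core have been measured. In a physicochemical assay for solubility, at pH 7 (on this read-out higher numbers stand for higher solubility and lower numbers for lower solubility), compound 1 `CC(C)(C)C(=O)N1Cc2c(NC(=O)c3ccncc3)n[nH]c2C1(C)C` gives 205000 nM. Compound 2 `CC(C)CC(=O)Nc1n[nH]c2c1CN(C(=O)C1CCN(C3CC3)CC1)C2(C)C` reaches only a limit of this assay, > 225000 nM, not a number (the limit of > 225000 nM in this assay, at which 1 of the 3 values shown sits). Compound 3 `CN1CCC(C(=O)N2Cc3c(NC(=O)c4cccs4)n[nH]c3C2(C)C)CC1` gives 155000 nM in this assay; its value and that of compound 1 sit within the usual scatter of each other. Compound 4 `CN1CCC(C(=O)N2Cc3c(NC(=O)c4ccc5ccccc5c4)n[nH]c3C2(C)C)CC1` has not yet been measured. It differs from compound 3 in one place (naphthalen-2-yl in place of thiophen-2-yl on a carbonyl carbon). Within the data shown here, no measured pair shows such a change, so the direction must be guessed. A lower number, beyond the scatter, is expected for compound 4, a step of a 3.9-fold lower number from compound 3 to compound 4 (0.59 log units; beyond the scatter). In this assay compound 4 is estimated at 40000 nM, between 10000 nM and 130000 nM.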

Compound 4, solubility: 219000 nM
For compound 4 the middle estimate is 5.5-fold (0.74 log units) below the measured one, and the stated range ends below it.
By their numbers in this assay, from the lowest: compounds 3, 1 and 4 (each within the scatter of the next). At a limit, above all of these: compound 2.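

In this assay, among these compounds, the one measured change on this carbonyl carbon is a 1.4-fold higher number from compound 3 to compound 4 (0.15 log units; within the scatter). Two six-membered aromatic rings of carbon only can therefore replace a five-membered aromatic ring with one hetero atom without a step beyond the scatter. Compound 2 gives no number here, only a limit of the assay: the limit of > 225000 nM in this assay, at which 1 of the 4 values shown sits.

On these data alone, it remains open how a ring carrying an amine or a carboxylic acid would read at this place. A longer alkyl chain on the same carbonyl carbon is equally untested by the compounds shown.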